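The source may hold more compounds than are shown below. What is called first, only, known or untested is meant among the compounds shown, and "the series" means these compounds.

Measured so far in a functional assay on HeLa cells (Homo sapiens) for cytotoxicity, read by MTT assay, with a stated time of 24 h; on this read-out lower numbers stand for stronger inhibition and higher numbers for weaker inhibition:

- Compound 1 `COc1cc(/C=C2\CN(C)C/C(=C\c3ccccc3F)C2=O)cc(OC)c1`: 5450 nM
- Compound 2 `CN1C/C(=C\c2ccc(C#N)cc2)C(=O)/C(=C/c2ccccc2F)C1`: 1340 nM
- Compound 3 `COc1cc(/C=C2\CN(C)C/C(=C\c3cc(OC)c(OC)c(OC)c3)C2=O)cc(OC)c1`: 2300 nM

Compound 3, at 2300 nM, lies within the usual scatter of compound 2, at 1340 nM. Compound 1, at 5450 nM, lies higher than compound 3, and that gap is beyond the scatter.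

The next compound to consider is compound 4 `COc1cc(/C=C2\CN(C)C/C(=C\c3ccc(C#N)cc3)C2=O)cc(OC)c1OC`. It keeps most of compound 3 but carries 4-cyanophenyl in place of 3,5-dimethoxyphenyl on a double-bonded chain carbon bound to a double-bonded ring carbon.

Within the data shown here, no measured pair of compounds gives this step directly, and the evidence is thin. Among the measured compounds, only compound 1 carries the leaving 3,5-dimethoxyphenyl without compound 3's other group, and compound 1 gives 5450 nM. Compound 2 carries the entering 4-cyanophenyl and gives 1340 nM. These two values point towards a lower number for the compound with the 4-cyanophenyl group, but they are a single comparison with a different group on the other side.

A moderate step to a lower number is therefore expected in this assay, estimated as a 2.6-fold lower number from compound 3 to compound 4 (0.41 log units; beyond the scatter). The estimated value for compound 4 is 900 nM, with an expected range from 350 nM to 2300 nM.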

Compound 4, half-maximal inhibitory concentration: 3420 nM
Compound 4: the middle estimate sits 3.8-fold (0.58 log units) below what was measured; measured number outside the range, above it.
By their numbers in this assay, from the lowest: compounds 2, 3, 4 and 1 (each within the scatter of the next, the first and the last beyond it).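

In this assay, putting 4-cyanophenyl in place of 3,5-dimethoxyphenyl on a double-bonded chain carbon bound to a double-bonded ring carbon gives a 1.5-fold higher number from compound 3 to compound 4 (0.17 log units; within the scatter), the first reading of a single change among these compounds. The two aromatic groups therefore cannot be told apart at this place in this read-out, even though one carries a nitrile and the other carries two methoxy groups. No measurement shown here offers an explanation for this result.

Among these compounds, this is only one pair on one background, so it remains open whether the same exchange would give a similar step with a different group elsewhere on the shared core. Going by these compounds, it also remains open whether this place would accept a group of another kind, such as a carboxylic acid or an amine on the aromatic ring, or a simple methyl group instead of the ring, without moving the number beyond the usual scatter.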